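Aryl variation on the ring amine of the shared core

A few compounds are considered here, and "the series" means these few. Any claim that something is new, unique, unknown or untested is made for them only; others in the source may bear on it.

Measured so far:
compound 1 `O=C1COc2ccc(NC(=O)C3CCN(c4ccccc4Br)CC3)cc2N1` — 160 nM
compound 2 `COc1cccc(N2CCC(C(=O)Nc3ccc4c(c3)NC(=O)CO4)CC2)c1` — 1420 nM

In a functional assay for antagonist activity at transient receptor potential cation channel subfamily V member 1 (Homo sapiens), read by FLIPR and calcium flux (on this read-out lower numbers stand for stronger inhibition and higher numbers for weaker inhibition), compound 2 gives the highest number of the two; its nearest neighbour is compound 1, and the step of an 8.9-fold higher number from compound 1 to compound 2 (0.95 log units; beyond the scatter) lies beyond the scatter. Compound 3 `O=C1COc2ccc(NC(=O)C3CCN(c4cc(F)c(F)c(F)c4)CC3)cc2N1` is not yet measured. It differs from compound 2 by 3,4,5-trifluorophenyl in place of 3-methoxyphenyl on an amine nitrogen in a ring. Going by the values given here, the only measured step that bears on this change is the one from compound 1 to compound 2, a modest one of an 8.9-fold higher number from compound 1 to compound 2 (0.95 log units; beyond the scatter), which shows that swapping the aryl group on the ring amine moves the number by about one order. Among the compounds with values here, no measured compound carries a fluorinated aryl, so the direction for compound 3 rests only on compound 1 showing a lower number with a halogenated aryl. A step of a 2.8-fold lower number from compound 2 to compound 3 (0.45 log units; beyond the scatter) toward lower numbers is expected in this assay. Compound 3 is estimated at 500 nM, with a range from 150 nM to 1800 nM.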

Compound 3, half-maximal inhibitory concentration: 59 nM
Estimate against measurement, compound 3: 8.5-fold (0.93 log units) above, outside the stated range (below it).
By their numbers in this assay, from the lowest: compound 3; then compound 1; then compound 2.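

In this assay, 3,4,5-trifluorophenyl on the amine nitrogen in a ring gives the lowest number of the three compounds, with a 24-fold lower number from compound 2 to compound 3 (1.38 log units; beyond the scatter) against 3-methoxyphenyl and a 2.7-fold lower number from compound 1 to compound 3 (0.43 log units; beyond the scatter) against 2-bromophenyl. Low numbers at this position are therefore not tied to 2-bromophenyl: an aryl group bearing only fluorine goes lower still, and both steps lie beyond the scatter. The data available give no reason for either step.

From the compounds shown here alone, whether a single fluorine, a trifluoromethyl or a nitrile on the phenyl ring would hold the number as low as 3,4,5-trifluorophenyl remains open. Also open, going by these compounds, is whether the high number of compound 2 follows from the methoxy group itself or from where it sits on the phenyl ring.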